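Chloro for Fluoro: Estimating Compound 4's Cytotoxicity

The source may hold more compounds than are shown below. What is called first, only, known or untested is meant among the compounds shown, and "the series" means these compounds.

Of the compounds shown here, three have been measured in a functional assay on HL-60 cells (Homo sapiens) for cytotoxicity, read by MTT assay, with a stated time of 72 h; on this read-out lower numbers stand for stronger inhibition and higher numbers for weaker inhibition. Compound 1 `COc1ccc(S(=O)(=O)c2nc3ccccc3nc2Nc2ccc(F)cc2)cc1` gives 610 nM in this assay. Compound 2 `COc1ccc(S(=O)(=O)c2nc3ccccc3nc2Nc2ccc(Cl)cc2)cc1` gives 19600 nM, and compound 3 `O=S(=O)(c1ccc(Br)cc1)c1nc2ccccc2nc1Nc1ccc(F)cc1` gives 260 nM, the lowest number of the three. Compound 3 differs from compound 1 by bromo in place of methoxy on an aromatic carbon, a change that brought a 2.3-fold lower number from compound 1 to compound 3 (0.37 log units; beyond the scatter). Compound 2 differs from compound 1 by chloro in place of fluoro on an aromatic carbon, a change that brought a 32-fold higher number from compound 1 to compound 2 (1.51 log units; beyond the scatter).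

Compound 4 `O=S(=O)(c1ccc(Br)cc1)c1nc2ccccc2nc1Nc1ccc(Cl)cc1` has not yet been measured. It differs from compound 3 by chloro in place of fluoro on an aromatic carbon, the same change as that between compound 1 and compound 2, which occurs twice among these compounds. For the measured compounds named here, compound 4 is expected to show a 23-fold higher number from compound 3 to compound 4 (1.36 log units; beyond the scatter) in this assay, to be set beside a 32-fold higher number from compound 1 to compound 2 (1.51 log units; beyond the scatter), the single earlier example of this change. One precedent fixes the size of the step only roughly, and the estimate stays somewhat below it. Compound 4 is accordingly estimated at 6000 nM in this assay, with a likely range from 1500 nM to 25000 nM.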

Compound 4, half-maximal inhibitory concentration: 16400 nM
Beside the measured number, compound 4's estimate is 2.7-fold (0.44 log units) below it; low and high end bracket the measured number.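

In this assay, chloro in place of fluoro gave a 63-fold higher number from compound 3 to compound 4 (1.80 log units; beyond the scatter), and this change carried over from the core of compound 1 to the core of compound 3 at much the same size: the same change on two cores in this assay, a 32-fold higher number (1.51 log units; beyond the scatter) from compound 1 to compound 2 and a 63-fold higher number (1.80 log units; beyond the scatter) from compound 3 to compound 4, 2.0-fold (0.29 log units) apart, within the scatter of two such steps. Bromo in place of methoxy gave a 1.2-fold lower number from compound 2 to compound 4 (0.08 log units; within the scatter), which lies within the scatter, yet the two instances of this change do not differ by more than the scatter: the same change on two cores in this assay, a 2.3-fold lower number (0.37 log units; beyond the scatter) from compound 1 to compound 3 and a 1.2-fold lower number (0.08 log units; within the scatter) from compound 2 to compound 4, 2.0-fold (0.29 log units) apart, within the scatter of two such steps. Across these four compounds, each change therefore behaved alike on both cores, but with only two instances of each in a single assay, this does not show that either step would hold on any other core, nor does it explain why the chloro step is so large.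

The compounds shown leave open how a methyl, a bromo or a methoxy would behave where fluoro and chloro sit. They also leave open what an amine or a carboxylic acid would do where methoxy and bromo sit.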